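The source may hold more compounds than are shown below. What is called first, only, known or untested is meant among the compounds shown, and "the series" means these compounds.

Compound 1, `Cc1ccc2nc(C(=O)Nc3c(F)cc(-c4cccc(F)c4)cc3F)c(C)c(C(=O)O)c2c1`: 2.11%
Compound 2, `CCc1ccc2nc(C(=O)Nc3c(F)cc(-c4cccc(F)c4)cc3F)c(C)c(C(=O)O)c2c1`: 0%
Compound 3, `CCOc1ccc2nc(C(=O)Nc3c(F)cc(-c4cccc(F)c4)cc3F)c(C)c(C(=O)O)c2c1`: 0.98%

These values come from a functional assay on Hep 3B2 cells (Homo sapiens) for antiproliferative activity, read by MTT assay, with a stated time of 24 h, tested at 0.05 ug/mL; a lower number here means a weaker effect, a higher number a stronger effect of the compound at the concentration tested. All three compounds share the same amide and acid part and differ in one group on the shared core. From compound 2 to compound 1 the change is hydrogen in place of methyl on a saturated chain carbon bound to an aromatic carbon, and the step it made was a number 2.1 percentage points higher from compound 2 to compound 1 (within the scatter). The core of compound 3 differs from that of compound 2 by ethoxy in place of ethyl on an aromatic carbon. Compound 4, `COc1ccc2nc(C(=O)Nc3c(F)cc(-c4cccc(F)c4)cc3F)c(C)c(C(=O)O)c2c1`, has not been measured; it differs from compound 3 by hydrogen in place of methyl on a saturated chain carbon bound to an oxygen on an aromatic ring. This is the same kind of change as from compound 2 to compound 1, but not the same: there the saturated chain carbon is bound to an aromatic carbon, here it is bound to an oxygen on an aromatic ring. Because the earlier step of a number 2.1 percentage points higher from compound 2 to compound 1 (within the scatter) stayed within the scatter, and because compound 3 gives 0.98%, the expected step is small: a number 0.5 percentage points higher from compound 3 to compound 4 (within the scatter). Compound 4 is expected to give about 1.5%, with a range from 0% to 7%.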

Compound 4, a percentage reported as inhibition, at one concentration (the size of the read-out at that concentration, not a potency): -0.66%
For compound 4 the middle estimate is 2.2 percentage points above the measured one, outside the stated range (below it).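

In this assay, hydrogen in place of methyl on a saturated chain carbon bound to an oxygen on an aromatic ring gave a number 1.6 percentage points lower from compound 3 to compound 4 (within the scatter), and this step can be set beside the same kind of change on the other core: the same change on two cores in this assay, a number 2.1 percentage points higher (within the scatter) from compound 2 to compound 1 and a number 1.6 percentage points lower (within the scatter) from compound 3 to compound 4, 3.8 percentage points apart, within the scatter of two such steps. The two cores therefore show no measurable difference in how this change behaves, and the methoxy compound also stays close to the other two, with a number 0.7 percentage points lower from compound 2 to compound 4 (within the scatter) and a number 2.8 percentage points lower from compound 1 to compound 4 (within the scatter). All these steps are small, and at this single concentration they show no effect of the change on either core, which does not prove that an effect would carry from one core to the other.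

The compounds shown leave open what an amine or a longer chain such as butyl would do on the shared core. They also leave open whether these compounds would separate at a higher concentration.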